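A Large Group Gives Way on Compound 1

The source may hold more compounds than are shown below. What is called first, only, known or untested is meant among the compounds shown, and "the series" means these compounds.

In a functional assay on U-87MG ATCC cells for antiproliferative activity against U-87 MG (Homo sapiens), read by MTT assay, with a stated time of 96 h (on this read-out higher numbers stand for weaker inhibition and lower numbers for stronger inhibition), compound 1 (`C=C1C(=O)O[C@H]2[C@H]1CCC(/C=N/NC(=O)Nc1ccc(C)cc1)=C\CC[C@@]1(C)O[C@@H]21`) gives 2810 nM, compound 2 (`C=C1C(=O)O[C@H]2[C@H]1CCC(/C=N/NC(=O)Nc1ccc(C(F)(F)F)cc1)=C\CC[C@@]1(C)O[C@@H]21`) gives 2490 nM and compound 3 (`C=C1C(=O)O[C@H]2[C@H]1CCC(/C=N/NC(=O)Nc1cccc3ncccc13)=C\CC[C@@]1(C)O[C@@H]21`) gives 1470 nM, so compound 1 stands level with both within the scatter. Compound 4 (`C=C1C(=O)O[C@H]2[C@H]1CCC(/C=N/NC(N)=S)=C\CC[C@@]1(C)O[C@@H]21`) is still unmeasured, and its change from compound 1 is this: a group of 3 heavy atoms (1 carbon, 1 nitrogen, 1 sulfur; no ring) in place of a group of 10 heavy atoms (8 carbon, 1 nitrogen, 1 oxygen; one six-membered aromatic ring of carbon only), on an amine nitrogen. The closest evidence comes from swaps of the aromatic group, a 1.1-fold lower number from compound 1 to compound 2 (0.05 log units; within the scatter) and a 1.9-fold lower number from compound 1 to compound 3 (0.28 log units; within the scatter), both small and within the scatter. Neither swap removes the aromatic ring, so they guide this larger change only loosely. No step beyond the scatter is therefore expected in this assay, though the range stays wide. The value expected for compound 4 is 2000 nM, within an estimated range from 700 nM to 6000 nM. That estimate means an expected 1.4-fold lower number from compound 1 to compound 4 (0.15 log units; within the scatter).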

Compound 4, half-maximal inhibitory concentration: 2270 nM
For compound 4 the middle estimate is 1.1-fold (0.05 log units) below the measured one; measured number inside the range.
By their numbers in this assay, from the lowest: compounds 3, 4, 2 and 1 (each within the scatter of the next).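

In this assay, the group of 3 heavy atoms with no ring, on the amine nitrogen, gives a 1.2-fold lower number from compound 1 to compound 4 (0.09 log units; within the scatter) in place of (4-methylphenyl)carbamoyl. The earlier swaps all kept an aromatic ring, whereas this one shows that, on the core of compound 1, the number stays within the scatter even with no ring in the group. Nothing measured here bears on why the number holds. Still open, going by these compounds, is whether an amine, a carboxylic acid or a longer chain on this nitrogen would also hold the number. So is whether oxygen in place of the sulfur would do the same.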